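A few compounds are considered here, and "the series" means these few. Any claim that something is new, unique, unknown or untested is made for them only; others in the source may bear on it.

Measured compounds:
- compound 1 `CC(/C=N/Nc1ccc([N+](=O)[O-])cc1)=N\NC(=O)c1ccccc1N`; in a functional assay on cells (Splenocyte, Mus musculus, strain BALB/c) for inhibition, read by scintillation counting and thymidine incorporation, with a stated time of 72 h (on this read-out higher numbers stand for weaker inhibition and lower numbers for stronger inhibition), compound 1 gives 4900 nM.
- compound 2 `CC(/C=N/Nc1ccc([N+](=O)[O-])cc1)=N\NC(=O)c1ccc(C(F)(F)F)cc1`; in this assay compound 2 reaches only a limit of the assay, > 12000 nM.

Going by the values given here, compound 1 holds the only actual number in this assay. The other recorded value is a limit, (the limit of > 12000 nM in this assay, at which 1 of the 2 values shown sits), and that is where compound 2 sits. Among the compounds with values here, the pair therefore yields no measured step, and nothing more can be drawn from it than what the two values show: compound 1 gives a number, compound 2 a limit.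

Compound 3 `CC(/C=N/Nc1ccc([N+](=O)[O-])cc1)=N\NC(=O)c1ccccc1Oc1ccccc1` is not yet measured. It differs from compound 1 in one place: phenoxy in place of amino on an aromatic carbon. Amino leaves and phenoxy enters, on an aromatic carbon of a six-membered aromatic ring of carbon only, ortho to a large group. Within the data shown here, no step between measured compounds covers a change of this kind, so the expectation rests on the structural change alone. A moderate move toward weaker inhibition is expected, possibly no larger than the scatter. Compound 3 is expected to give about 9000 nM in this assay, within 3000 nM to 30000 nM. This amounts to an expected step of a 1.8-fold higher number from compound 1 to compound 3 (0.26 log units; within the scatter).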

Compound 3, half-maximal inhibitory concentration: > 12000 nM
Compound 3: no number, only a limit; the forecaster's own chance of this, stated with the estimate: 35%; at least 1.3-fold (0.12 log units) between middle value and limit.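

In this assay compound 3 reaches only a limit of the assay, > 12000 nM. Even as a bound, phenoxy in place of amino on this aromatic carbon, ortho to a large group, gives an at least 2.4-fold higher number from compound 1 to compound 3 (0.38 log units; beyond the scatter), so this position is the first in the series where a single change can be read, and the read-out does not tolerate this exchange without loss. Compound 1 remains the only compound with an actual number, and the second compound sharing its core through this position's change adds no further figure, leaving most of the values shown at one limit: the limit of > 12000 nM in this assay, at which 2 of the 3 values shown sit.

On these data alone, the true size of the step stays unknown, and the data do not separate the loss of the amino group from the arrival of the phenoxy group with its extra aromatic ring. A methoxy or hydroxy group, or a dimethylamino group, on the same aromatic carbon would help to tell these apart, and any such compound that gives a real number would turn this bound into a measured step.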